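This account rests on a few compounds, and the source may have more. Where it says the series, first, only, none or still open, it means among the compounds named here.

Measured so far:
compound 2 `CCN(C(=O)c1nc(C)ccc1-n1nccn1)[C@@H](C)Cn1nnc(-c2ccc(F)cc2)n1` — 1.84 nM
compound 1 `Cc1ccc(-n2nccn2)c(C(=O)N[C@@H](C)Cn2ccc(-c3ccc(F)cn3)n2)c1` — 10.1 nM

Compound 2 holds the lowest number of the two in a functional assay on cells for antagonist activity at Orexin/Hypocretin receptor type 1 (Homo sapiens), read by fluorescence and calcium flux, with a stated time of 30 min; on this read-out lower numbers stand for stronger inhibition and higher numbers for weaker inhibition; the nearest, compound 1, sits higher, beyond the scatter. Compound 3 `CCN(C(=O)c1nc(C)ccc1-c1ncccn1)[C@@H](C)Cn1nnc(-c2ccc(F)cc2)n1` carries pyrimidin-2-yl in place of 2H-1,2,3-triazol-2-yl on an aromatic carbon relative to compound 2. Within the data shown here, no measured pair differs by this change alone, so no step for it is known; a modest step is expected, not clearly beyond the scatter and without a settled direction. Compound 3 is therefore estimated at 3.5 nM, within 1.2 nM to 12 nM. The step this estimate means is expected as a 1.9-fold higher number from compound 2 to compound 3 (0.28 log units; within the scatter).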

Compound 3, half-maximal inhibitory concentration: 6.15 nM
Estimate against measurement, compound 3: 1.8-fold (0.24 log units) below; low and high end bracket the measured number.
By their numbers in this assay, from the lowest: compound 2; then compounds 3 and 1 (each within the scatter of the next).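

In this assay, among these compounds, the swap of 2H-1,2,3-triazol-2-yl for pyrimidin-2-yl gives the first single-place comparison, with a 3.3-fold higher number from compound 2 to compound 3 (0.52 log units; beyond the scatter) on the aromatic carbon ortho to a large group. This position therefore accepts a six-membered aromatic ring with 2 hetero atoms, at a modest loss of inhibition. Nothing at hand accounts for this step.

Ring size and hetero atom count change together here, leaving their separate shares open. Phenyl or pyrazol-1-yl on this carbon would bear on that question.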